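The source may hold more compounds than are shown below. What is called first, only, known or untested is meant among the compounds shown, and "the series" means these compounds.

Compound 1, `Cc1ccc(Cn2cc(COc3ccc4c(=O)ccoc4c3)nn2)cc1`, gives in a functional assay on SGC-7901 cells (Homo sapiens) for cytotoxicity, read by MTT assay, with a stated time of 48 h (a higher number here means a weaker inhibitor, a lower number a stronger inhibitor), only the limit > 100000 nM.
Compound 2, `N#Cc1ccc(Cn2cc(COc3ccc4c(=O)ccoc4c3)nn2)cc1`, gives in this assay only the limit > 100000 nM.
Compound 3, `O=c1ccoc2cc(OCc3cn(Cc4ccc([N+](=O)[O-])cc4)nn3)ccc12`, gives in this assay only the limit > 100000 nM.

Compound 3 thus stands nowhere in particular on the numbers shown: its value is a limit, and it shares that standing with both other compounds, because of the limit of > 100000 nM in this assay, at which 3 of the 3 values shown sit. On these data alone, the three changes among the measured compounds all exchange one group on the same aromatic carbon, yet none of them can be read: a step that the two limits leave unreadable from compound 1 to compound 2, a step that the two limits leave unreadable from compound 1 to compound 3 and a step that the two limits leave unreadable from compound 2 to compound 3 are each hidden between two limits, so their size and direction are unknown.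

Compound 4, `CC(C)(C)c1ccc(Cn2cc(COc3ccc4c(=O)ccoc4c3)nn2)cc1`, has not yet been measured. It differs from compound 3 in one place: tert-butyl in place of nitro on an aromatic carbon. Among the measured compounds shown here, the only measured steps that bear on this change are the three unreadable ones, which exchange one substituent for another at the same aromatic carbon without ever producing a numerical value. There is therefore no basis for expecting a step beyond the scatter in either direction in this assay, and the most reasonable expectation is that compound 4 again sits at the limit.

Compound 4 is estimated at 100000 nM, with a range from 30000 nM to 300000 nM. The expected step of a number no higher from compound 3 to compound 4 (the limit leaves the size open) is accordingly about nil.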

Compound 4, half-maximal inhibitory concentration: > 100000 nM
Compound 4: no number, only a limit; the forecaster's own chance of this, stated with the estimate: 80%; the middle value sits exactly at the limit.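

In this assay compound 4 gives only > 100000 nM, which is a limit. No step between compound 4 and compound 1, compound 2 or compound 3 can be read, because all of them sit at the same limit: the limit of > 100000 nM in this assay, at which 4 of the 4 values shown sit.

The compounds shown leave open how methyl, cyano, nitro and tert-butyl on this aromatic carbon compare, in size or direction.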